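Enone reversal on the shared core: expectation for compound 4

A few compounds are considered here, and "the series" means these few. Any claim that something is new, unique, unknown or untested is made for them only; others in the source may bear on it.

compound 1 `COc1ccc(C(=O)/C=C/c2cc(-c3cc(OC)c(OC)c(OC)c3)n3nc(-c4ccccc4)cc3n2)cc1` — 79800 nM
compound 2 `COc1cc(C(=O)/C=C/c2cc(-c3cc(OC)c(OC)c(OC)c3)n3nc(-c4ccccc4)cc3n2)cc(OC)c1OC` — >= 100000 nM
compound 3 `COc1ccc(-c2cc(C(=O)/C=C/c3ccc(Cl)cc3)nc3cc(-c4ccccc4)nn23)cc1OC` — 39100 nM

In an ADME assay on HEK293 cells (Homo sapiens) for antiproliferative activity, read by MTT assay, with a stated time of 24 h (a lower number here means a stronger inhibitor, a higher number a weaker inhibitor), compound 1 gives 79800 nM, the higher of the two numbers shown. For compound 2 the result in this assay is a limit of the assay, >= 100000 nM. Going by the values given here, the only measured single step, an at least 1.2-fold higher number from compound 1 to compound 2 (0.09 log units; that floor lies within the scatter), is bounded by the limit of >= 100000 nM in this assay, at which 1 of the 3 values shown sits, and shows nothing beyond the scatter. Compound 4 `COc1cc(-c2cc(C(=O)/C=C/c3ccccc3)nc3cc(-c4ccccc4)nn23)cc(OC)c1OC` differs from compound 1 by (2-phenylethenyl)carbonyl in place of 2-((4-methoxyphenyl)carbonyl)ethenyl on an aromatic carbon. Among the compounds with values here, no measured step covers this change directly; compound 3 carries the same arrangement of carbonyl and ethenyl on the core with other substituents and gives 39100 nM, below compound 1. On that basis the step of a 1.6-fold lower number from compound 1 to compound 4 (0.20 log units; within the scatter) is expected to be small and downward. Compound 4 is estimated at 50000 nM, between 20000 nM and 100000 nM.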

Compound 4, half-maximal inhibitory concentration: 44800 nM
Compound 4: middle estimate off by 1.1-fold (0.05 log units), on the high side; low and high end bracket the measured number.
By their numbers in this assay, from the lowest: compounds 3, 4 and 1 (each within the scatter of the next, the first and the last beyond it). At a limit, above all of these: compound 2.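

In this assay this position accepts the change with a 1.8-fold lower number from compound 1 to compound 4 (0.25 log units; within the scatter): reversing the enone on the aromatic carbon next to the ring nitrogen and losing the methoxy together leave the number within the scatter. The earlier single step altered only the aryl group on the carbonyl and ended at a limit, whereas this one alters the link to the shared core and gives two readable numbers. Nothing shown accounts for the size of this step.

Going by these compounds, one step carries both the reversal and the loss of the methoxy, and their separate shares stay open. Also open, on these data alone, is whether an amine or a carboxylic acid on the phenyl of the (2-phenylethenyl)carbonyl group would move the number.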